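Swapping the aryl on the shared core: compound 2 to compound 4

The source may report more compounds than this note shows. Statements on the series, on what has been measured and on what is new or still open speak of the compounds shown alone.

Of the compounds shown here, three of one shared core have been tested so far in a functional assay on BGC-823 cells (Homo sapiens) for inhibition, read by CCK-8 assay, with a stated time of 48 h; a lower number here means a stronger inhibitor, a higher number a weaker inhibitor. Compound 1 `Cc1ccc(C2=NN(C3=NC(c4ccccc4)CS3)C(c3ccc4ccccc4c3)C2)cc1C` gives 6570 nM. Compound 2 `Cc1ccc(C2=NN(C3=NC(c4ccccc4)CS3)C(c3cccc4ccccc34)C2)cc1C` gives 8460 nM, and compound 3 `O=C1CSC(N2N=C(c3ccc(Cl)cc3)CC2c2cccc3ccccc23)=N1` gives 16400 nM. On these numbers compound 2 stands second highest of three; its nearest neighbour is compound 1, and its furthest is compound 3, both within the scatter, so no order among the three can be claimed.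

For the measured compounds named here, the one step between compounds that differ in a single place is a 1.3-fold higher number from compound 1 to compound 2 (0.11 log units; within the scatter), which moves naphthalen-1-yl in place of naphthalen-2-yl on a saturated ring carbon and stays within the scatter.

Compound 4 `COc1ccc(C2=NN(C3=NC(c4ccccc4)CS3)C(c3cccc4ccccc34)C2)cc1` has not yet been measured. It differs from compound 2 by 4-methoxyphenyl in place of 3,4-dimethylphenyl on a carbon with a double bond to nitrogen. Going by the values given here, no measured step touches this position or this pair of groups, so nothing measured bears directly on it; compound 3 carries yet another aryl on the same carbon but differs from the others in more than one place. He therefore expects a step of about a 1.1-fold higher number from compound 2 to compound 4 (0.03 log units; within the scatter) in this assay, that is none beyond the scatter. His estimate for compound 4 is 9000 nM, within 4000 nM to 20000 nM.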

Compound 4, half-maximal inhibitory concentration: 9510 nM
The estimate for compound 4 lay 1.1-fold (0.02 log units) below the measured number; measured number inside the range.
By their numbers in this assay, from the lowest: compounds 1, 2, 4 and 3 (each within the scatter of the next, the first and the last beyond it).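

In this assay, for the compounds shown here, a 1.1-fold higher number from compound 2 to compound 4 (0.05 log units; within the scatter) is the first step read at the carbon with a double bond to nitrogen, and it leaves compound 2 and compound 4 indistinguishable within the scatter, so this position accepts 4-methoxyphenyl in place of 3,4-dimethylphenyl without a measurable difference. The entering group brings an oxygen and a hydrogen-bond acceptor that the leaving group lacks, yet in this one pair, with the naphthalen-1-yl group held constant, that difference is not matched by a step beyond the scatter. Nothing available on these compounds offers a reason for this outcome.

On these data alone, the reading rests on a single pair, so it remains open whether the same exchange would read alike with the naphthalen-2-yl group of compound 1, or how the 4-chlorophenyl group of compound 3 would compare on the core of compound 2, since compound 3 differs from the others in more than one place. As far as these compounds go, it also remains open whether an amine or a carboxylic acid on this aryl ring, or a longer alkoxy chain in place of methoxy, would move the number beyond the scatter.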